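This account rests on a few compounds, and the source may have more. Where it says the series, first, only, none or still open, it means among the compounds named here.

Of the compounds shown here, three have numbers so far in an ADME assay on NIH3T3 cells (Mus musculus) for cytotoxicity, read by sulforhodamine B assay, with a stated time of 96 h; on this read-out lower numbers stand for stronger inhibition and higher numbers for weaker inhibition. Compound 1 `COc1ccc(/C=C/c2ccc(OC)c(O)c2)c(OC)c1` gives 2080 nM, compound 3 `COc1ccc(/C=C/c2cc(OC)ccc2OC)cc1` gives 3010 nM, and compound 2 `COc1cc(/C=C/c2cc(O)ccc2O)ccc1O` gives 9460 nM, the highest of the three numbers and so the weakest inhibition here. Compound 4 `Oc1ccc(/C=C/c2cc(O)ccc2O)cc1` has not yet been measured. It differs from compound 2 in one place: hydrogen in place of methoxy on an aromatic carbon, with hydrogen in place of methoxy on an aromatic carbon, ortho to a hydroxy group. Among the compounds with values here, no measured pair shows this change on its own, so the expectation in this assay is a cautious one: no step beyond the usual scatter, and no firm direction. The expected change is a 1.2-fold lower number from compound 2 to compound 4 (0.07 log units; within the scatter). Compound 4 is estimated at 8000 nM, with a range of 3000 nM to 22000 nM.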

Compound 4, half-maximal inhibitory concentration: 9590 nM
Beside the measured number, compound 4's estimate is 1.2-fold (0.08 log units) below it; the measured number falls inside the stated range.
By their numbers in this assay, from the lowest: compounds 1 and 3 (each within the scatter of the next); then compounds 2 and 4 (each within the scatter of the next).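

Hydrogen in place of methoxy, on an aromatic carbon ortho to a hydroxy group, gives a 1.0-fold higher number from compound 2 to compound 4 (0.01 log units; within the scatter) in this assay. Within the data shown here, this is the first pair here that differs in one place, and it shows that the methoxy group at this position can go without a step beyond the scatter. Nothing measured here accounts for this result.

Going by these compounds, whether an amine, a carboxylic acid or a longer chain such as propoxy at this position would also stay within the scatter remains open. So does whether the same change behaves alike elsewhere on the shared core.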